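The compounds below may be only part of what the source reports. "The series", "measured", "known", "first", "only" and "open" are said of these compounds alone.

Of the compounds shown here, three have been measured in a functional assay on the whole organism (strain Wister albino) for inhibition, with Rattus norvegicus as the target, read by paw edema, with stated times of 1 h and 3 h, at a dose of 50 mg/kg by the intraperitoneal route; a higher number here means more inhibition at the dose given (going by the name of the read-out), a lower number less inhibition. Compound 1 `CN1C[C@@H](c2ccc(F)cc2)[C@@]2(Cc3ccccc3C2=O)[C@@]12C(=O)Nc1ccccc12` gives 21.1%, compound 2 `CN1C(=O)[C@@]2(c3ccccc31)N(C)C[C@@H](c1ccc(F)cc1)[C@@]21Cc2ccccc2C1=O` gives 26.9%, and compound 3 `CN1C[C@@H](c2ccco2)[C@@]2(Cc3ccccc3C2=O)[C@@]12C(=O)Nc1ccccc12` gives 38.8%. Compound 2 is thus the second highest of the three numbers; its gap to compound 1 lies within the scatter, while compound 3 sits beyond it. Compound 4 `COc1ccc([C@@H]2CN(C)[C@]3(C(=O)N(C)c4ccccc43)[C@]23Cc2ccccc2C3=O)cc1` differs from compound 2 by methoxy in place of fluoro on an aromatic carbon. Going by the values given here, no measured step alters exactly this position. The nearest case is a number 17.7 percentage points higher from compound 1 to compound 3 (beyond the scatter), a modest gain on exchanging the aryl group itself, whereas a number 5.8 percentage points higher from compound 1 to compound 2 (within the scatter) shows a change elsewhere leaving the number essentially unchanged. Among the compounds with values here, with no direct precedent, compound 4 is expected to stay near compound 2, so a number 3.1 percentage points higher from compound 2 to compound 4 (within the scatter) is estimated to fall within the scatter. Compound 4 is therefore estimated at 30%, with a range from 15% to 45%.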

Compound 4, a percentage reported as inhibition, in the whole organism at one dose (the size of the read-out at that dose, not a potency): 3.3%
Estimate against measurement, compound 4: 26.7 percentage points above, outside the stated range (below it).
By their numbers in this assay, from the lowest: compound 4; then compounds 1 and 2 (each within the scatter of the next); then compound 3.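

In this assay, the aromatic carbon para to a large group proves sensitive: going from 4-fluorophenyl to 4-methoxyphenyl gives a number 23.6 percentage points lower from compound 2 to compound 4 (beyond the scatter). Alongside a number 17.7 percentage points higher from compound 1 to compound 3 (beyond the scatter), this shows that changes to this aryl group can move the number either way. Nothing available explains the loss. From the compounds shown here alone, it remains open whether a hydroxy or an amino group at the same place would give a similarly low number, and whether methoxy in place of fluoro would have the same effect on compound 1, which keeps the amide hydrogen.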